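Methoxy Removal on the Aryl Ring and Cytotoxicity

A few compounds are considered here, and "the series" means these few. Any claim that something is new, unique, unknown or untested is made for them only; others in the source may bear on it.

Compound 1 `COc1ccc(-c2cc(/C=C/C(=O)c3ccc(N)cc3)[nH]n2)cc1`: 90%
Compound 2 `COc1cc(-c2cc(/C=C/C(=O)c3ccc(N)cc3)[nH]n2)cc(OC)c1OC`: 94%

In a functional assay on U-251 cells (Homo sapiens) for cytotoxicity, read by sulforhodamine B assay, with a stated time of 48 h, tested at 0.1 uM (a lower number here means a stronger effect, a higher number a weaker effect of the compound at the concentration tested), compound 1 gives 90%, and in this assay compound 2 gives 94%. Compound 2 has the highest of the two numbers, but its nearest neighbour, compound 1, lies within the scatter of it, so the two compounds cannot be told apart on this evidence and both show only a weak effect at the concentration tested.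

Compound 3 `COc1ccc(-c2cc(/C=C/C(=O)c3ccc(N)cc3)[nH]n2)cc1OC` has not yet been measured in this assay. It differs from compound 2 in one place: hydrogen in place of methoxy on an aromatic carbon. Among the compounds with values here, no step between measured compounds exists to calibrate this change; since compounds 1 and 2 do not differ beyond the scatter, no step beyond the scatter is expected for a number 2 percentage points lower from compound 2 to compound 3 (within the scatter). For compound 3 the estimated value in this assay is 92%, with an expected range from 82% to 100%.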

Compound 3, a percentage reported as activity, at one concentration (the size of the read-out at that concentration, not a potency): 95%
Compound 3: middle estimate off by 3 percentage points, on the low side, within the range that was stated.
By their numbers in this assay, from the lowest: compounds 1, 2 and 3 (each within the scatter of the next).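

In this assay, within the data shown here, hydrogen in place of methoxy on this aromatic carbon, ortho to a methoxy group, gives a number 1 percentage points higher from compound 2 to compound 3 (within the scatter), the first calibrated reading of this change at this position. Methoxy in place of hydrogen on an aromatic carbon gives a number 5 percentage points higher from compound 1 to compound 3 (within the scatter), so neither removing nor adding a methoxy group separates these three compounds at the concentration tested. Nothing available explains this result.

On these data alone, whether a different group at this position, such as a hydroxyl, an amine or a longer chain like butoxy, would shift the number beyond the scatter remains open. As far as these compounds go, it is also open whether the three compounds, which cannot be told apart here, would separate at a higher concentration or in another cell line.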